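The compounds below may be only part of what the source reports. "The series", "measured", "known", "first", "only" and "open" are said of these compounds alone.

Measured compounds:
compound 1, `CC(O)(CSc1cccc(C(F)(F)F)c1)C(=O)Nc1cc(C(F)(F)F)cc(C(F)(F)F)c1`, 9670 nM
compound 2, `CC(O)(CSc1ccccc1C(F)(F)F)C(=O)Nc1cc(C(F)(F)F)cc(C(F)(F)F)c1`, 4370 nM
compound 3, `CC(O)(CSc1cccc(OC(F)(F)F)c1)C(=O)Nc1cc(C(F)(F)F)cc(C(F)(F)F)c1`, 6420 nM

All three were tested in a functional assay on CWR22R cells (Homo sapiens) for antiproliferative activity, read by fluorescence and propidium iodide staining, with a stated time of 96 h; a higher number here means a weaker inhibitor, a lower number a stronger inhibitor. Compound 3 holds the second highest of the three numbers. Its nearest neighbour is compound 2, at a 1.5-fold higher number from compound 2 to compound 3 (0.17 log units; within the scatter), and its furthest is compound 1, at a 1.5-fold lower number from compound 1 to compound 3 (0.18 log units; within the scatter); both of these gaps lie within the scatter, so the three cannot be ranked against each other on these numbers.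

Compound 4, `CC(O)(CSc1ccccc1OC(F)(F)F)C(=O)Nc1cc(C(F)(F)F)cc(C(F)(F)F)c1`, has not been measured. It differs from compound 3 in one place: 2-(trifluoromethoxy)phenyl in place of 3-(trifluoromethoxy)phenyl on a sulfur.

For the measured compounds named here, one measured step bears directly on this change. Going from compound 1 to compound 2 puts 2-(trifluoromethyl)phenyl in place of 3-(trifluoromethyl)phenyl on the sulfur, the same shift of a group but with trifluoromethyl instead of trifluoromethoxy, and it gave a 2.2-fold lower number from compound 1 to compound 2 (0.34 log units; beyond the scatter), a modest step beyond the scatter. The comparison of compound 1 with compound 3 shows that swapping trifluoromethyl for trifluoromethoxy at the same spot changed little, a 1.5-fold lower number from compound 1 to compound 3 (0.18 log units; within the scatter).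

On that basis a modest lowering of the number is expected for compound 4, a 2.1-fold lower number from compound 3 to compound 4 (0.33 log units; beyond the scatter). Compound 4 is therefore estimated at 3000 nM in this assay, within a range of 1500 nM to 7000 nM.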

Compound 4, half-maximal inhibitory concentration: 2940 nM
The estimate for compound 4 lay 1.0-fold (0.01 log units) above the measured number, and the stated range covers the measured number.
By their numbers in this assay, from the lowest: compounds 4, 2, 3 and 1 (each within the scatter of the next, the first and the last beyond it).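

In this assay, the shift of a group on the sulfur now has a second case: 2-(trifluoromethoxy)phenyl in place of 3-(trifluoromethoxy)phenyl gives a 2.2-fold lower number from compound 3 to compound 4 (0.34 log units; beyond the scatter), so the lowering first seen with trifluoromethyl, a 2.2-fold lower number from compound 1 to compound 2 (0.34 log units; beyond the scatter), recurs with trifluoromethoxy and is of much the same size. For the compounds shown here, with both changes made at once, the gap grows to a 3.3-fold lower number from compound 1 to compound 4 (0.52 log units; beyond the scatter), and compound 4 is the only compound of the four whose number stands beyond the scatter of compound 1 without being a plain trifluoromethyl shift. Trifluoromethoxy in place of trifluoromethyl on an aromatic carbon also gets a second reading, a 1.5-fold lower number from compound 2 to compound 4 (0.17 log units; within the scatter), which leaves compound 2 and compound 4 unseparated and matches the first reading: the same change on two cores in this assay, a 1.5-fold lower number (0.18 log units; within the scatter) from compound 1 to compound 3 and a 1.5-fold lower number (0.17 log units; within the scatter) from compound 2 to compound 4, 1.0-fold (0.01 log units) apart, within the scatter of two such steps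

The compounds shown leave open whether the lowering from this shift depends on the two fluorinated groups at all, as a chloro group, a methoxy group or a bare phenyl on the sulfur does not stand among them. They also do not say what a sulfone in place of the sulfur would do to the number.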